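The source may report more compounds than this note shows. Statements on the series, on what has been measured and on what is new or still open speak of the compounds shown alone.

Series notes. Among the measured compounds shown here, compound 1 `C/C(=C\CC/C(C)=C/CC[C@@H]1[C@@]2(C)CCC(=O)C(C)(C)[C@H]2CC[C@@]1(C)O)CC/C=C(\C)C(=O)OCc1cn(-c2cccc(C)c2)nn1` is the only member with a numeric reading so far: in a functional assay on DU-145 cells (Homo sapiens) for antiproliferative activity, read by MTT assay, with a stated time of 48 h (a lower number here means a stronger inhibitor, a higher number a weaker inhibitor), compound 1 gives 137000 nM. Compound 2 `C/C(=C\CC/C(C)=C/CC[C@@H]1[C@@]2(C)CCC(=O)C(C)(C)[C@H]2CC[C@@]1(C)O)CC/C=C(\C)C(=O)OCc1cn(C[C@@H]2O[C@H](n3ccc(=O)[nH]c3=O)[C@H]3OC(C)(C)O[C@H]32)nn1` returns only a limit in this assay, > 150000 nM, and so contributes no number. For the measured compounds named here, the remaining entry is therefore (the limit of > 150000 nM in this assay, at which 1 of the 2 values shown sits), which leaves compound 1 standing alone as the single quantified point; no measured step between two numbers exists within the set.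

Compound 3 `C/C(=C\CC/C(C)=C/CC[C@@H]1[C@@]2(C)CCC(=O)C(C)(C)[C@H]2CC[C@@]1(C)O)CC/C=C(\C)C(=O)OCc1cn(-c2ccc(Cl)cc2)nn1` is the next member to be read. Against compound 1 the change is 4-chlorophenyl in place of 3-methylphenyl on an aromatic nitrogen. The leaving 3-methylphenyl and the entering 4-chlorophenyl occupy the same aromatic nitrogen, and nothing else in the shared core moves.

Going by the values given here, no measured pair covers this exchange, so its size in this assay can only be expected, not read off. Given the weak reading of compound 1 at 137000 nM, the step of a 1.1-fold lower number from compound 1 to compound 3 (0.06 log units; within the scatter) is expected to stay within the scatter, with no firm direction. Compound 3 is accordingly estimated at 120000 nM, with a range from 50000 nM to 200000 nM, and a real chance that only a limit is reported.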

Compound 3, half-maximal inhibitory concentration: > 150000 nM
Compound 3 ended at the assay's limit; the forecaster's own chance of this, stated with the estimate: 35%; middle value at least 1.2-fold (0.09 log units) away from the limit.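

In this assay compound 3 gives only a limit, > 150000 nM. Among the compounds shown here, this is the first measured exchange on this aromatic nitrogen between two aryl groups, and it reads as an at least 1.0-fold higher number from compound 1 to compound 3 (0.03 log units; that floor lies within the scatter); 4-chlorophenyl in place of 3-methylphenyl therefore brings no quantified gain, and the size of the step stays unread beyond that floor. The single number from compound 1 is now the exception in the set, and a second aryl group on this nitrogen has not added another: the limit of > 150000 nM in this assay, at which 2 of the 3 values shown sit.

On these data alone, whether any group on this aromatic nitrogen can give a clearly stronger reading than compound 1 stays open, and an unsubstituted phenyl, a 4-aminophenyl or a 4-carboxyphenyl would each probe the same place. Also open, as far as these compounds go, is how much of the weak reading belongs to the shared core and how much to the group on this nitrogen, which these compounds cannot separate.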